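Thiazole-fused series: aryl versus phenethyl substituent

This account rests on a few compounds, and the source may have more. Where it says the series, first, only, none or still open, it means among the compounds named here.

Measured so far in a functional assay on CCRF-CEM cells (Homo sapiens) for inhibition, read by cell counting, with a stated time of 3 days; on this read-out lower numbers stand for stronger inhibition and higher numbers for weaker inhibition:
compound 1 `C=C(Br)C(=O)Nc1cccc(-c2cn3nc(-c4ccc(OC)c(OC)c4)sc3n2)c1` gives 380 nM
compound 2 `C=C(Br)C(=O)Nc1cccc(-c2cn3nc(CCc4ccccc4)sc3n2)c1` gives 4200 nM

Compound 2 stands highest of the two numbers in this assay, the nearest being compound 1 at an 11-fold higher number from compound 1 to compound 2 (1.04 log units; beyond the scatter). Compound 3 `C=C(Br)C(=O)Nc1cccc(-c2cn3nc(-c4ccc(Cl)cc4)sc3n2)c1` differs from compound 2 by 4-chlorophenyl in place of phenethyl on an aromatic carbon. Among the compounds with values here, the only step that bears on it is the one from compound 1 to compound 2, where an aryl group gave way to phenethyl with a large rise in the number. Returning to a directly attached aryl group is therefore expected to lower the number, an expected step of a 7.0-fold lower number from compound 2 to compound 3 (0.85 log units; beyond the scatter). For compound 3 the estimate in this assay is 600 nM, with a range of 200 nM to 2000 nM.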

Compound 3, half-maximal inhibitory concentration: 3200 nM
The estimate for compound 3 lay 5.3-fold (0.73 log units) below the measured number, outside the stated range (above it).
By their numbers in this assay, from the lowest: compound 1; then compounds 3 and 2 (each within the scatter of the next).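

In this assay, a directly attached aryl group does not by itself lower the number: with 4-chlorophenyl in place of phenethyl, the change is a 1.3-fold lower number from compound 2 to compound 3 (0.12 log units; within the scatter) and leaves the two substituents unresolved. The identity of the aryl group does matter at this position, with an 8.4-fold higher number from compound 1 to compound 3 (0.93 log units; beyond the scatter) on replacing 3,4-dimethoxyphenyl by 4-chlorophenyl. No available evidence explains this difference.

From the compounds shown here alone, it remains open whether both methoxy groups are needed for the lower number of compound 1. Also open, going by these compounds, is how an amine on the phenyl ring would compare.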